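From 4-methoxyphenyl to 2,4-dichlorophenyl in a cytotoxicity series

This account rests on a few compounds, and the source may have more. Where it says the series, first, only, none or still open, it means among the compounds named here.

Measured in a functional assay on MGC-803 cells (Homo sapiens) for cytotoxicity, read by MTT assay, with a stated time of 72 h; a lower number here means a stronger inhibitor, a higher number a weaker inhibitor:
- compound 1 `CN(C)c1ccc(C=C2C(=O)N(c3ccc(Cl)cc3)N(c3ccc(Cl)cc3)C2=O)cc1`: 80200 nM
- compound 2 `COc1ccc(C=C2C(=O)N(c3ccc(Cl)cc3)N(c3ccc(Cl)cc3)C2=O)cc1`: > 128000 nM (a limit, not a number)
- compound 3 `CC(=C1C(=O)N(c2ccc(Cl)cc2)N(c2ccc(Cl)cc2)C1=O)c1ccc(O)cc1`: 42800 nM

All three values are high, which means weak effects on these cells. Compound 2 stands at the limit of > 128000 nM in this assay, at which 1 of the 3 values shown sits, so its place is known only as a limit.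

Compound 4 `O=C1C(=Cc2ccc(Cl)cc2Cl)C(=O)N(c2ccc(Cl)cc2)N1c1ccc(Cl)cc1` keeps the core of compound 2 and changes one group: 2,4-dichlorophenyl in place of 4-methoxyphenyl on a double-bonded chain carbon bound to a double-bonded ring carbon. Here 2,4-dichlorophenyl takes the place of 4-methoxyphenyl on a double-bonded chain carbon bound to a double-bonded ring carbon.

Among the measured compounds shown here, only one measured step touches this group: an at least 1.5-fold higher number from compound 1 to compound 2 (0.20 log units; that floor lies within the scatter). That step swaps a different pair of groups and its floor lies within the scatter, so it is a poor guide to size. The real numbers in hand are compound 1 with 80200 nM and compound 3 with 42800 nM. Compound 4 is therefore expected to fall in that same weak range, though it may also end up as a limit. The expected change, towards a lower number, is an at least 1.8-fold lower number from compound 2 to compound 4 (0.26 log units; that floor lies within the scatter). The estimate for compound 4 is 70000 nM, with an expected range of 25000 nM to 128000 nM.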

Compound 4, half-maximal inhibitory concentration: > 128000 nM
Compound 4 gave a limit, no number; the forecaster's own chance of this, stated with the estimate: 35%; middle value at least 1.8-fold (0.26 log units) from the limit.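

In this assay compound 4 gives > 128000 nM, which is a limit of the assay and not a number. With 4-methoxyphenyl and 2,4-dichlorophenyl, two groups that differ in their atoms and in their count of hydrogen-bond acceptors, this double-bonded chain carbon has now twice given a result with no number, and the step between these two compounds cannot be read, as both ends are limits: the limit of > 128000 nM in this assay, at which 2 of the 4 values shown sit. Among the compounds shown here, the one step that can be read is an at least 1.5-fold higher number from compound 1 to compound 4 (0.20 log units; that floor lies within the scatter), so it gives only a floor and does not separate compound 4 from compound 1 beyond the usual variation between repeated measurements.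

As far as these compounds go, what stays open is how far beyond the limit compound 2 and compound 4 truly lie, and so whether replacing 4-methoxyphenyl with 2,4-dichlorophenyl changes the effect on these cells at all. Also open, from the compounds shown here alone, is whether a phenyl ring carrying a carboxylic acid or a nitrile at this place on the shared core would give a readable value.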